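Defining the dioxolane stereocentre on the compound 2 side chain

A few compounds are considered here, and "the series" means these few. Any claim that something is new, unique, unknown or untested is made for them only; others in the source may bear on it.

Measured so far in a functional assay on A549 cells (Homo sapiens) for cytotoxicity, read by MTT assay, with a stated time of 72 h; a higher number here means a weaker inhibitor, a lower number a stronger inhibitor:
compound 1 `CN1CCN(CCCCCCn2c3c(c4ccccc42)C(=O)c2c[n+]([O-])c4ccccc4c2C3=O)CC1`: 330 nM
compound 2 `CC1(C)OCC(Cn2cc(Cn3c4c(c5ccccc53)C(=O)c3c[n+]([O-])c5ccccc5c3C4=O)nn2)O1`: 80 nM
compound 3 `O=C1c2c[n+]([O-])c3ccccc3c2C(=O)c2c1c1ccccc1n2CCCCN1CCNCC1`: 540 nM

Compound 2 gives the lowest number of the three; compound 1 and compound 3 both lie beyond the scatter from it, so compound 2 is the strongest inhibitor measured here. Among the compounds with values here, the one single-point step recorded, a 1.6-fold higher number from compound 1 to compound 3 (0.21 log units; within the scatter), concerns the chain-borne amine and says nothing about stereochemistry.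

Compound 4 `CC1(C)OC[C@H](Cn2cc(Cn3c4c(c5ccccc53)C(=O)c3c[n+]([O-])c5ccccc5c3C4=O)nn2)O1` has not yet been measured. It differs from compound 2 only in this way: the two compounds have the same atoms and bonds; at least one stereo element is drawn with a configuration in one of them and without one in the other: 1 of 1 stereo elements differ; a stereocentre at a saturated ring carbon is drawn without a configuration in compound 2 and S in compound 4. Nothing leaves and nothing enters; compound 4 is one defined configuration of what compound 2 describes without a configuration. Within the data shown here, no measured step bears on a change of this kind. Where a compound without a drawn configuration already gives a number, a single defined configuration can give the same number or a lower one, and only rarely a markedly higher one, so the expected direction is neutral to slightly lower.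

The estimate for compound 4 is 70 nM, within 35 nM to 160 nM, an expected step of a 1.1-fold lower number from compound 2 to compound 4 (0.06 log units; within the scatter), which is taken to lie within the scatter.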

Compound 4, half-maximal inhibitory concentration: 340 nM
Compound 4: middle estimate off by 4.9-fold (0.69 log units), on the low side; the measured number lies above the stated range.
By their numbers in this assay, from the lowest: compound 2; then compounds 1, 4 and 3 (each within the scatter of the next).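

In this assay, the stereocentre at a saturated ring carbon on the side chain of compound 2 is not a neutral feature: drawing it S gives a 4.3-fold higher number from compound 2 to compound 4 (0.63 log units; beyond the scatter). The earlier single-place step, a 1.6-fold higher number from compound 1 to compound 3 (0.21 log units; within the scatter), concerned the chain-borne amine and stayed within the scatter, so this stereocentre is the only place in the series where a single change is seen to move the number beyond the scatter. With atoms and bonds unchanged, the step can be tied to one structural difference only: the fact that one of compounds 2 and 4 is drawn with a defined configuration and the other without, at the place where they differ

As far as these compounds go, the drawing of compound 2 does not state which configuration or mixture of configurations lies behind its number, so it remains open whether the R configuration accounts for the lower value of compound 2 or whether something else separates the two samples. Also open, from the compounds shown here alone, is how this position reads when the ring is replaced by an open-chain diol or a primary amine, and whether the S configuration gives the same step on a side chain without the triazole.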